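Pyridin-3-yl for pyridin-2-yl: stability still open

The source may hold more compounds than are shown below. What is called first, only, known or untested is meant among the compounds shown, and "the series" means these compounds.

Measured in an ADME assay on microsomes from liver (Homo sapiens) for metabolic stability, with a stated time of 0.5 h; a lower number here means that less of the compound is left, a higher number that more of the compound is left:
- compound 1 `O=C(COc1ccc2[nH]c(=O)c(-c3nccs3)c(CCc3ccccc3)c2c1)NC1(c2ccccc2)CC1`: 46%
- compound 2 `CC(C)(NC(=O)COc1ccc2[nH]c(=O)c(-c3ccccn3)c(CCc3ccccc3)c2c1)c1ccccc1`: "not determined" (no result reported)

Compound 2 has no single number to stand on: in this assay compound 2 is reported as "not determined" (no result reported). Next comes compound 3 `CC(C)(NC(=O)COc1ccc2[nH]c(=O)c(-c3cccnc3)c(CCc3ccccc3)c2c1)c1ccccc1`. The change is pyridin-3-yl in place of pyridin-2-yl on an aromatic carbon, with pyridin-3-yl in place of pyridin-2-yl on an aromatic carbon. Within the data shown here, no measured step shows what this swap does, so no shift beyond the usual scatter is expected, in either direction. Among the measured compounds shown here, the only available number is that of compound 1 at 46%, and compound 1 carries other groups. For compound 3 the expected value is 45%, with an estimated range of 22% to 70%.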

Compound 3, percent of the compound remaining: 83%
Beside the measured number, compound 3's estimate is 38 percentage points below it; measured number above the stated range.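

No step can be read between compound 2 and compound 3: in this assay compound 2 has no reported result, while compound 3 gives 83% as a single value. Going by these compounds, what pyridin-3-yl in place of pyridin-2-yl does in this assay stays open. Nothing measured here offers an explanation for the value of compound 3.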